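Cytotoxicity of three anilides and a bromothiophene analogue

The source may report more compounds than this note shows. Statements on the series, on what has been measured and on what is new or still open speak of the compounds shown alone.

Measured compounds:
compound 1, `O=C(Nc1ccc(NC2CCCCC2)cc1Cl)c1cc(Cl)ccc1O`: 68300 nM
compound 2, `O=C(Nc1ccc(NCc2ccc(Cl)cc2)cc1Cl)c1cc(Cl)ccc1O`: 59700 nM
compound 3, `O=C(Nc1ccc(NCc2ccc(O)nc2)cc1Cl)c1cc(Cl)ccc1O`: 98500 nM

The three compounds share one core and differ only in the group carried on a nitrogen on an aromatic ring. In an ADME assay on A549 cells (Homo sapiens) for cytotoxicity, read by resazurin assay, with a stated time of 48 h (a lower number here means that less compound is tolerated, a higher number that more compound is tolerated), compound 1 gives 68300 nM, the second highest of the three numbers, but all three lie within the scatter of one another: a 1.1-fold lower number from compound 1 to compound 2 (0.06 log units; within the scatter) and a 1.4-fold higher number from compound 1 to compound 3 (0.16 log units; within the scatter), and between the other two a 1.6-fold higher number from compound 2 to compound 3 (0.22 log units; within the scatter). Nothing among them separates a ring of carbon only from a benzyl or a pyridylmethyl group.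

Compound 4, `O=C(Nc1ccc(NCc2ccc(Br)s2)cc1Cl)c1cc(Cl)ccc1O`, has not yet been measured. It differs from compound 1 by (5-bromothiophen-2-yl)methyl in place of cyclohexyl on a nitrogen on an aromatic ring. Both steps away from compound 1 bear on this change, and neither left the scatter, so no step beyond the scatter is expected in this assay here either; the estimate for the step is a 1.1-fold lower number from compound 1 to compound 4 (0.02 log units; within the scatter). Compound 4 is therefore expected to give about 65000 nM, within a range from 35000 nM to 120000 nM.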

Compound 4, half-maximal cytotoxic concentration: 20700 nM
Compound 4: the middle estimate sits 3.1-fold (0.50 log units) above what was measured; measured number below the stated range.
By their numbers in this assay, from the lowest: compound 4; then compounds 2, 1 and 3 (each within the scatter of the next).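

In this assay, among the compounds shown here, the position on the nitrogen is not indifferent to its group: (5-bromothiophen-2-yl)methyl gives the first steps here beyond the scatter, with a 3.3-fold lower number from compound 1 to compound 4 (0.52 log units; beyond the scatter) against cyclohexyl. On the same saturated chain carbon, 5-bromothiophen-2-yl also departs from both other aromatic rings, with a 2.9-fold lower number from compound 2 to compound 4 (0.46 log units; beyond the scatter) against 4-chlorophenyl and a 4.8-fold lower number from compound 3 to compound 4 (0.68 log units; beyond the scatter) against 6-hydroxypyridin-3-yl, so the change is seen against all three earlier groups, though each step is modest. Nothing available accounts for this drop in the tolerated concentration.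

The compounds shown leave open whether the step belongs to the bromine or to the thiophene ring. A thiophen-2-ylmethyl group carrying no bromine, or a 4-bromobenzyl group, on the same nitrogen would separate the two.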